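Replacing a dimethylamino group with acetylpiperazine in compound 3

The source may report more compounds than this note shows. Statements on the series, on what has been measured and on what is new or still open speak of the compounds shown alone.

Among the measured compounds shown here, compound 2, `CN(C)Cc1ccc2c(c1)CC[C@H](N(C)C(=O)c1ccc(-c3ccc(F)cc3)cn1)C2`, is one of two compounds measured in a functional assay on HEK293 cells for antagonist activity at melanin-concentrating hormone receptor 1 (Homo sapiens); a higher number here means a weaker inhibitor, a lower number a stronger inhibitor. In this assay compound 2 gives 20 nM, while compound 1, `CN(C)Cc1ccc2c(c1)CC[C@H](N(C)C(=O)c1ccc(-c3ccc(Cl)cc3)nc1)C2`, gives 12 nM; the gap between the two lies within the usual scatter, so the two numbers cannot be told apart. For the measured compounds named here, no single-point step between measured compounds exists in this set.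

Compound 3, `CC(=O)N1CCN(Cc2ccc3c(c2)CC[C@H](N(C)C(=O)c2ccc(-c4ccc(F)cc4)cn2)C3)CC1`, has not yet been measured in this assay. It differs from compound 2 by 4-acetylpiperazin-1-yl in place of dimethylamino on a saturated chain carbon bound to an aromatic carbon. Going by the values given here, there is no measured pair that shows what such an exchange does, so any expectation rests on the structural change alone. A modest weakening is expected, on the order of a 2.3-fold higher number from compound 2 to compound 3 (0.35 log units; beyond the scatter), with a wide range to reflect the lack of precedent. For compound 3 the estimated value in this assay is 45 nM, with a range from 12 nM to 180 nM.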

Compound 3, inhibition constant: 302 nM
For compound 3 the middle estimate is 6.7-fold (0.83 log units) below the measured one; the measured number lies above the stated range.
By their numbers in this assay, from the lowest: compounds 1 and 2 (each within the scatter of the next); then compound 3.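

In this assay, among the compounds shown here, the exchange of dimethylamino for 4-acetylpiperazin-1-yl on a saturated chain carbon bound to an aromatic carbon gives a 15-fold higher number from compound 2 to compound 3 (1.18 log units; beyond the scatter) and so provides the first comparison in this set between compounds that differ in one place. It shows that this position does not accept every amine-bearing group alike, and that this particular exchange, from 3 to 9 heavy atoms with a six-membered non-aromatic ring added, costs a large step in the number. Nothing available here accounts for that step.

The single exchange changes the ring and the acetyl group together, so the compounds shown do not separate the two. A piperazine without the acetyl group, a morpholine or a pyrrolidine at the same place would leave this question open no longer.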